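Cyclopentyl amide in place of trifluoromethylphenyl amide

A few compounds are considered here, and "the series" means these few. Any claim that something is new, unique, unknown or untested is made for them only; others in the source may bear on it.

Among the three compounds measured in an assay (strain Wistar) for displacement of a labelled ligand from adenosine receptor A1 (Rattus norvegicus), read by scintillation counting (on this read-out higher numbers stand for weaker inhibition and lower numbers for stronger inhibition), compound 2 `O=C(Nc1nc(-c2ccccc2)nc2c1nnn2Cc1ccccc1)c1ccccc1C(F)(F)F` gives 550 nM, the lowest of the three numbers. Compound 1 `CCOc1ccccc1C(=O)Nc1nc(-c2ccccc2)nc2c1nnn2Cc1ccccc1` gives 1850 nM and compound 3 `COc1ccccc1C(=O)Nc1nc(-c2ccccc2)nc2c1nnn2Cc1ccccc1` gives 1520 nM. The steps of a 3.4-fold lower number from compound 1 to compound 2 (0.53 log units; beyond the scatter) and a 2.8-fold higher number from compound 2 to compound 3 (0.44 log units; beyond the scatter) each exchange one group on an aromatic carbon, whereas a 1.2-fold lower number from compound 1 to compound 3 (0.09 log units; within the scatter) stays within the scatter. Compound 4 `O=C(Nc1nc(-c2ccccc2)nc2c1nnn2Cc1ccccc1)C1CCCC1` differs from compound 2 in that (cyclopentyl in place of 2-(trifluoromethyl)phenyl on a carbonyl carbon). Within the data shown here, none of the measured steps exchanges the whole six-membered aromatic ring for a non-aromatic one, so no step bears directly on this change; the expectation rests on the spread of the three numbers. The expected step is a 2.2-fold higher number from compound 2 to compound 4 (0.34 log units; beyond the scatter), a modest rise at most. Compound 4 is estimated at 1200 nM, within a range from 300 nM to 5000 nM.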

Compound 4, inhibition constant: 2.5 nM
For compound 4 the middle estimate is 480-fold (2.68 log units) above the measured one; measured number below the stated range.
By their numbers in this assay, from the lowest: compound 4; then compound 2; then compounds 3 and 1 (each within the scatter of the next).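

In this assay the group on the carbonyl carbon turns out to weigh far more than the earlier exchanges on the aromatic ring suggested: cyclopentyl gives a 220-fold lower number from compound 2 to compound 4 (2.34 log units; beyond the scatter) and likewise a 610-fold lower number from compound 3 to compound 4 (2.78 log units; beyond the scatter) and a 740-fold lower number from compound 1 to compound 4 (2.87 log units; beyond the scatter). All three steps are large, whereas the steps among compound 1, compound 2 and compound 3 are modest at most, so a substituted aromatic ring at this place is not required for a low number. Nothing measured here accounts for this gain. Still open, on these data alone, is whether a cyclohexyl or cyclobutyl ring, or an open butyl chain, on the carbonyl carbon would keep such a low number.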